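The source may report more compounds than this note shows. Statements on the series, on what has been measured and on what is new or still open speak of the compounds shown alone.

Of the compounds shown here, two have been measured so far. Compound 1 `CC(C)COc1ccc(-c2cn(C)c3cc(C(=O)NS(=O)(=O)C4CC4)c(F)cc23)cn1` and compound 2 `Cn1cc(-c2ccc(C(F)F)cc2)c2cc(F)c(C(=O)NS(=O)(=O)C3CC3)cc21` share the same core and differ in the aromatic group that hangs from it. In an ADME assay on microsomes from liver (Mus musculus) for metabolic stability, with a stated time of 10 min, tested at 0.5 uM (a higher number here means that more of the compound is left, a lower number that less of the compound is left), compound 1 gives 98%. In this assay compound 2 gives 86%. Compound 1 thus stands highest of the two numbers, and its nearest neighbour, compound 2, lies a distance below it that is beyond the usual scatter.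

The next compound, compound 3 `CC(C)COc1ncc(-c2cn(C)c3cc(C(=O)NS(=O)(=O)C4CC4)c(F)cc23)cc1Cl`, is made from compound 1 by a single change: chloro in place of hydrogen on an aromatic carbon.

Going by the values given here, no step between two measured compounds describes this kind of change, so the size of its effect in this assay is not known from the data. With compound 1 already near the top of the scale at 98%, little room remains for a rise, and a small fall that stays within the scatter seems the most probable outcome. The step from compound 1 to compound 3 is therefore expected to be a number 5 percentage points lower from compound 1 to compound 3 (within the scatter). Compound 3 is estimated to give 93% in this assay, within a range from 82% to 100%.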

Compound 3, percent of the compound remaining: 100%
Estimate against measurement, compound 3: 7 percentage points below, and the stated range covers the measured number.
By their numbers in this assay, from the lowest: compound 2; then compounds 1 and 3 (each within the scatter of the next).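

Putting chloro in place of hydrogen on an aromatic carbon, ortho to the isobutoxy group and two atoms from the ring nitrogen, gives a number 2 percentage points higher from compound 1 to compound 3 (within the scatter) in this assay. Going by these compounds alone, this is the first step at this position, and it shows that the position takes a chloro without a change that can be told from the scatter; compound 1 at 98% and compound 3 at 100% both stand at the top of the scale, so this read-out has almost no room left to show any gain. Nothing at hand gives a reason for this result, so it stays a plain observation about one pair of compounds.

As far as these compounds go, whether the same position would tolerate a larger or different group, such as a nitrile, a methoxy group or an amine, remains open, since a single chloro says little about other groups there. Also open, from the compounds shown here alone, is whether a chloro would leave the number as little moved with a shorter or longer chain in place of the isobutoxy group, where a lower starting value could reveal a step in either direction.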